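The source may report more compounds than this note shows. Statements on the series, on what has been measured and on what is new or still open speak of the compounds shown alone.

Compound 1 `Cc1ccc(-c2nn(-c3ccccc3)cc2CNc2ccccc2)cc1`: > 100000 nM in an ADME assay on MDBK cells (Bos taurus) for cytotoxicity, read by MTT assay, with a stated time of 72 h (on this read-out lower numbers stand for higher toxicity in this test and higher numbers for lower toxicity in this test), a limit.
Compound 2 `Cc1ccc(NCc2cn(-c3ccccc3)nc2-c2ccc(Cl)cc2)cc1`: > 100000 nM in this assay, a limit.
Compound 3 `Cc1ccc(-c2nn(-c3ccccc3)cc2CNc2ccc(Br)cc2)cc1`: > 100000 nM in this assay, a limit.

Compound 3 therefore stands only at the assay limit; no number is known for it, and the same holds for both other compounds, since (the limit of > 100000 nM in this assay, at which 3 of the 3 values shown sit). Compound 4 `FC(F)(F)c1ccc(-c2nn(-c3ccccc3)cc2CNc2ccc(Br)cc2)cc1` differs from compound 3 in one place: trifluoromethyl in place of methyl on an aromatic carbon. For the measured compounds named here, the only measured step, a step that the two limits leave unreadable from compound 1 to compound 3, gives no readable size, because both of its ends are limits. Going by the values given here, no measured step therefore bears on the change to compound 4, and no direction can be drawn from the series. Compound 4 is expected to remain near the limit, with an estimated 150000 nM (50000 nM to 400000 nM). The step that the limit leaves unreadable from compound 3 to compound 4 is accordingly expected to lie within the scatter.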

Compound 4, half-maximal cytotoxic concentration: 64000 nM
For compound 4 the middle estimate is 2.3-fold (0.37 log units) above the measured one; the range from low to high includes it.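

In this assay, for the compounds shown here, compound 4 gives 64000 nM as the first value that is a number and not a limit. From the compounds shown here alone, the change from 4-methylphenyl to 4-(trifluoromethyl)phenyl is an at least 1.5-fold lower number from compound 3 to compound 4 (0.19 log units; that floor lies within the scatter) and brings the read-out under the limit at this position, while the true size of the step stays unknown. Going by these compounds, whether trifluoromethyl here gives a number without the bromo group, on the core of compound 1, remains open. Also open, on these data alone, is what an amine or a carboxylic acid at this position would give.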